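This account rests on a few compounds, and the source may have more. Where it says the series, first, only, none or still open, it means among the compounds named here.

Within the data shown here, compound 1 `O=C(NNC(=O)c1ccccc1Br)c1ccc(-n2cccc2)cc1` is the only member of this small set with a number behind it. In an ADME assay on A549 cells (Homo sapiens) for cytotoxicity, read by MTT assay, with a stated time of 72 h (a higher number here means a weaker inhibitor, a lower number a stronger inhibitor), compound 1 gives 201000 nM, a weak result by any measure. Two relatives entered the same study but yielded no number there: compound 2 `Cc1ccc(C)n1-c1ccc(C(=O)N/N=C/c2ccc(O)cc2)cc1` is recorded in this assay as "not determined" (no result reported), and compound 3 `Cc1ccc(C)n1-c1ccc(C(=O)N/N=C/c2c(Cl)cccc2Cl)cc1` likewise stands in this assay at "not determined" (no result reported). So compound 1 stands alone on the numbers shown, with nothing to rank it against, and no step between two measured compounds is available to calibrate what a structural change does here.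

The step under consideration leads from compound 1 to compound 4 `O=C(NNC(=O)c1ccc(-n2cccc2)cc1)c1ccccc1`. The counted difference is hydrogen in place of bromo on an aromatic carbon. Only one heavy atom leaves, no ring is touched and no donor or acceptor is lost, so the shared core is kept entire. Among the measured compounds shown here, with no measured step to lean on, the expectation for compound 4 is a step of a 1.2-fold higher number from compound 1 to compound 4 (0.09 log units; within the scatter), which is within the scatter, tending towards no change or a slightly weaker result. Compound 4 is estimated at 250000 nM in this assay, with a range from 100000 nM to 600000 nM.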

Compound 4, half-maximal inhibitory concentration: 215000 nM
Estimate against measurement, compound 4: 1.2-fold (0.07 log units) above; the measured number falls inside the stated range.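

Among these compounds, replacing bromo with hydrogen gives the only measured step in this set, and in this assay it reads a 1.1-fold higher number from compound 1 to compound 4 (0.03 log units; within the scatter). At this place, on an aromatic carbon of a six-membered aromatic ring of carbon only and ortho to a large group, the bromine can therefore be lost with the shared core kept whole, and the two numbers cannot be told apart, so that the 2-bromophenyl to phenyl difference registers no effect that this read-out can resolve. No separate measurement bears on this outcome, and the result stands as an observation without an explanation.

With only bromo and hydrogen shown at this place, it remains open whether other groups there, such as an amine, a methoxy group or a carboxylic acid, would also leave the number within the scatter, or whether a step beyond it can be reached from this position at all. Also open, on these data alone, is how the rest of the set relates to these two, as compound 2 and compound 3 carry no number in this assay and offer no further comparison.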